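From an Octyl Chain to a Chlorinated Aryl Amine

This account rests on a few compounds, and the source may have more. Where it says the series, first, only, none or still open, it means among the compounds named here.

Compound 1 `CCCCCCCCNc1nc(SCc2ccc(C(F)(F)F)cc2)nc2ccccc12` carries an octylamino group on the shared core. In a functional assay on MDA-MB-231 cells (Homo sapiens) for cytotoxicity, read by MTT assay, with a stated time of 72 h (a higher number here means a weaker inhibitor, a lower number a stronger inhibitor), compound 1 gives 22300 nM. Going by the values given here, its only measured companion is compound 2 `FC(F)(F)c1ccc(CSc2nc(N3CCCCC3)c3ccccc3n2)cc1`, in which a piperidin-1-yl takes the place of the octylamino; in this assay compound 2 gives 28400 nM. The step of a 1.3-fold higher number from compound 1 to compound 2 (0.11 log units; within the scatter) shows that exchanging the substituent at this position left the read-out essentially where it was, so compound 1 and compound 2 stand together within the scatter of each other.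

Compound 3 `FC(F)(F)c1ccc(CSc2nc(Nc3ccc(Cl)cc3)c3ccccc3n2)cc1` has not yet been measured. It differs from compound 1 by 4-chlorophenyl in place of octyl on a nitrogen on an aromatic ring. Among the compounds with values here, no measured step replaces an open chain on this nitrogen with an aromatic ring, so the only guide is the single small step between compound 1 and compound 2. On that basis a shift beyond the scatter is not expected in either direction, though the range must stay wide. For compound 3 the expected value in this assay is 20000 nM, between 6000 nM and 60000 nM. This corresponds to an expected step of a 1.1-fold lower number from compound 1 to compound 3 (0.05 log units; within the scatter).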

Compound 3, half-maximal inhibitory concentration: 15100 nM
The estimate for compound 3 lay 1.3-fold (0.12 log units) above the measured number, within the range that was stated.
By their numbers in this assay, from the lowest: compounds 3, 1 and 2 (each within the scatter of the next).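

In this assay, the new result extends the comparison at this position from an open chain and a piperidin-1-yl to an aromatic ring carrying chlorine: 4-chlorophenyl in place of octyl on the nitrogen gives a 1.5-fold lower number from compound 1 to compound 3 (0.17 log units; within the scatter) as its step, and (4-chlorophenyl)amino in place of piperidin-1-yl gives a 1.9-fold lower number from compound 2 to compound 3 (0.27 log units; within the scatter) as its step. Both steps stay within the scatter, so even this exchange of an eight-carbon chain for a six-membered aromatic ring does not separate compound 3 from compound 1, and the three groups shown cannot be ranked at this position. Nothing available accounts for this lack of separation, as no supporting measurement bears on the result.

The three compounds leave open whether any group at this position can move the read-out beyond the scatter, for example a plain phenyl, a 4-methoxyphenyl, a shorter butyl chain or a chain ending in a carboxylic acid. They also leave open whether the same flat picture would hold if the trifluoromethyl group elsewhere on the shared core were replaced by a nitrile or a methoxy group.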